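Methoxy in Place of Fluoro on the Distal Ring

The compounds below may be only part of what the source reports. "The series", "measured", "known", "first", "only" and "open" are said of these compounds alone.

Measured so far in a functional assay on MDA-MB-231 cells (Homo sapiens) for antiproliferative activity, read by MTT assay, with a stated time of 72 h; a lower number here means a stronger inhibitor, a higher number a weaker inhibitor:
- compound 1, `COc1cc(CCc2ccccc2)cc(OC)c1O`: compound 1 gives > 25000 nM, which is a limit of the assay (the limit of > 25000 nM in this assay, at which 1 of the 3 values shown sits).
- compound 2, `COc1cc(CCc2ccccc2Cl)cc(OC)c1O`: compound 2 gives 21100 nM.
- compound 3, `COc1cc(CCc2ccccc2F)cc(OC)c1O`: compound 3 gives 9220 nM.

Compound 3 holds the lowest of the two numbers; the nearest is compound 2, with a 2.3-fold lower number from compound 2 to compound 3 (0.36 log units; beyond the scatter). Compound 4, `COc1ccccc1CCc1cc(OC)c(O)c(OC)c1`, differs from compound 3 by methoxy in place of fluoro on an aromatic carbon. Among the compounds with values here, the steps that bear on this change are an at least 2.7-fold lower number from compound 1 to compound 3 (0.43 log units; beyond the scatter) and a 2.3-fold lower number from compound 2 to compound 3 (0.36 log units; beyond the scatter), both swaps at the same aromatic carbon and both modest. Methoxy has not been tried there, so the direction is open; a modest rise in the number seems the likelier outcome. Compound 4 is therefore estimated at 15000 nM, between 4000 nM and 40000 nM, a step of a 1.6-fold higher number from compound 3 to compound 4 (0.21 log units; within the scatter).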

Compound 4, half-maximal inhibitory concentration: > 25000 nM
Compound 4: a limit, no number (the forecaster's own chance of this, stated with the estimate: 25%); at least 1.6-fold (0.22 log units) between middle value and limit.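

In this assay compound 4 gives a limit of the assay, not a number: the limit of > 25000 nM in this assay, at which 2 of the 4 values shown sit. Methoxy in place of fluoro on this aromatic carbon, ortho to a large group, gives an at least 2.7-fold higher number from compound 3 to compound 4 (0.43 log units; beyond the scatter), so methoxy does not keep the gain seen with fluoro. Methoxy in place of chloro gives an at least 1.1-fold higher number from compound 2 to compound 4 (0.07 log units; that floor lies within the scatter), so these two groups cannot be ranked.

The step that joins the two limits cannot be read. As far as these compounds go, whether a methyl group or an amine on this carbon would give a number as low as fluoro does remains open.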